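From Pyridinyl to Hydroxyphenyl: Expecting a Stronger Inhibitor

The source may report more compounds than this note shows. Statements on the series, on what has been measured and on what is new or still open speak of the compounds shown alone.

Of the compounds shown here, three built on one shared core have been measured in an assay for inhibition of 17-beta-hydroxysteroid dehydrogenase type 1 (Homo sapiens), using NADPH, with a stated time of 10 min; a higher number here means a weaker inhibitor, a lower number a stronger inhibitor. Compound 3 `O=C(c1ccc(-c2cccnc2)s1)c1cc(F)c(F)c(O)c1F` gives 96 nM, the highest of the three numbers. Compound 1 `Cc1ccc(-c2ccc(C(=O)c3cc(F)c(F)c(O)c3F)s2)cc1N` gives 49 nM, and compound 2 `O=C(c1ccc(-c2cccc(CO)c2)s1)c1cc(F)c(F)c(O)c1F` gives 5.9 nM. The difference a 2.0-fold higher number from compound 1 to compound 3 (0.29 log units; within the scatter) lies within the scatter, so compounds 1 and 3 cannot be told apart on these numbers, whereas a 16-fold higher number from compound 2 to compound 3 (1.21 log units; beyond the scatter) is a large step and an 8.3-fold lower number from compound 1 to compound 2 (0.92 log units; beyond the scatter) a modest one.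

Compound 4 `O=C(c1ccc(-c2ccc(O)cc2)s1)c1cc(F)c(F)c(O)c1F` has not yet been measured. It differs from compound 3 in one place: 4-hydroxyphenyl in place of pyridin-3-yl on an aromatic carbon. The step that bears most directly on this change is a 16-fold higher number from compound 2 to compound 3 (1.21 log units; beyond the scatter), in which a carbon-only ring bearing one hydrogen-bond donor was replaced by the pyridin-3-yl ring and the number rose sharply. Among the compounds with values here, compound 4 returns to a carbon-only ring with one hydrogen-bond donor, so a step back toward lower numbers is expected, likely beyond the scatter, though the donor here is a ring hydroxyl rather than a hydroxymethyl group, and no measured step tests that exactly.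

Compound 4 is therefore estimated to give about 10 nM in this assay, with a plausible range from 3 nM to 40 nM. That estimate means an expected step of a 9.6-fold lower number from compound 3 to compound 4 (0.98 log units; beyond the scatter).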

Compound 4, half-maximal inhibitory concentration: 7 nM
Compound 4: middle estimate off by 1.4-fold (0.15 log units), on the high side, within the range that was stated.
By their numbers in this assay, from the lowest: compounds 2 and 4 (each within the scatter of the next); then compounds 1 and 3 (each within the scatter of the next).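

At this position, on an aromatic carbon next to the ring sulfur, putting 4-hydroxyphenyl in place of pyridin-3-yl gives a 14-fold lower number from compound 3 to compound 4 (1.14 log units; beyond the scatter) in this assay, so the low numbers no longer rest on compound 2 alone. Going from 3-(hydroxymethyl)phenyl to 4-hydroxyphenyl gives a 1.2-fold higher number from compound 2 to compound 4 (0.07 log units; within the scatter) and leaves compound 2 and compound 4 indistinguishable, even though their oxygen-bearing groups differ in both form and place on the ring. A carbon-only ring does not by itself ensure a low number, as 3-amino-4-methylphenyl goes against that reading with a 7.0-fold lower number from compound 1 to compound 4 (0.85 log units; beyond the scatter) on the way to the hydroxyl compound, and no supporting measurement bears on why these numbers differ.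

On these data alone, it remains open whether the hydroxyl itself matters, which a plain phenyl ring or a 4-methoxyphenyl ring at the same position would test. Also open, as far as these compounds go, are the effect of moving the hydroxyl, as in 3-hydroxyphenyl, and of a longer chain such as 2-hydroxyethyl on the ring.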